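Notes on compound 4: acetyl to propanoyl change

The source may report more compounds than this note shows. Statements on the series, on what has been measured and on what is new or still open speak of the compounds shown alone.

Measured compounds:
compound 1 `COc1cccc(CCCNC(C)=O)c1`: 23.3 nM
compound 2 `CCCOc1ccc(OC)cc1CCCNC(C)=O`: 400 nM
compound 3 `COc1cc(CCCNC(C)=O)ccc1OCc1ccccc1`: 8980 nM

In an assay on CHO cells for displacement of a labelled ligand from melatonin receptor type 1A (Homo sapiens), read by scintillation counting, with a stated time of 60 min (a higher number here means a weaker inhibitor, a lower number a stronger inhibitor), compound 1 gives 23.3 nM. Among the measured compounds shown here, compound 2 gives 400 nM, and the single one-place step measured so far is a 17-fold higher number from compound 1 to compound 2 (1.23 log units; beyond the scatter). Compound 3 gives 8980 nM, the highest number of the three; its distance from compound 2 and from compound 1 is in each case beyond the scatter, so compound 3 is the weakest inhibitor of the set as measured.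

Compound 4 `CCC(=O)NCCCc1ccc(OCc2ccccc2)c(OC)c1` differs from compound 3 by methyl in place of hydrogen on a saturated chain carbon bound to a carbonyl carbon. For the measured compounds named here, no measured step touches the amide end of the chain: the only step available concerns a substituent on an aromatic carbon, and it says nothing about the acyl group. With no bearing evidence, the working expectation is a step of no size beyond the scatter, a 1.0-fold higher number from compound 3 to compound 4 (0.00 log units; within the scatter), and compound 4 is therefore estimated at 9000 nM in this assay, with a range of 3000 nM to 27000 nM to cover the uncertainty of an untested change.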

Compound 4, inhibition constant: 2010 nM
For compound 4 the middle estimate is 4.5-fold (0.65 log units) above the measured one; measured number below the stated range.
By their numbers in this assay, from the lowest: compound 1; then compound 2; then compound 4; then compound 3.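

In this assay the amide end of the chain proves responsive: acetyl to propanoyl, methyl in place of hydrogen on a saturated chain carbon bound to a carbonyl carbon, moves the number beyond the scatter (a 4.5-fold lower number from compound 3 to compound 4 (0.65 log units; beyond the scatter)). Among the compounds shown here, the only earlier one-place step concerned an aromatic carbon and went towards a weaker inhibitor (a 17-fold higher number from compound 1 to compound 2 (1.23 log units; beyond the scatter)), whereas this change at the acyl end goes towards a stronger one. No measured evidence on the reason for this shift is available.

As far as these compounds go, this position is represented by a single pair, so it remains open whether propanoyl in place of acetyl has the same effect on the core of compound 1. The compounds shown also do not tell how a longer chain such as butanoyl, or a branched group such as isobutyryl, would read here.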